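This account rests on a few compounds, and the source may have more. Where it says the series, first, only, none or still open, it means among the compounds named here.

Measured so far in an ADME assay on S9 fraction from liver (Rattus norvegicus, strain Sprague-Dawley) for metabolic stability, read by LC-MS, using NADPH, with stated times of 5 min and 60 min, tested at 5 uM; a higher number here means that more of the compound is left, a lower number that less of the compound is left:
compound 1 `COc1cc(C2CN(C(=O)c3cc(OCCO)ccn3)C2)ccc1OCc1ccc(C2CC2)cc1`: 51%
compound 2 `COc1cc(C2CN(C(=O)c3cc(OC[C@@H](O)CO)ccn3)C2)ccc1OCc1ccc(C2CC2)cc1`: 61%
compound 3 `COc1cc(C2CN(C(=O)c3cc(OCCCC(=O)O)ccn3)C2)ccc1OCc1ccc(C2CC2)cc1`: 100%

Compound 3 stands highest of the three at 100%, and its distance to each of the other two lies beyond the scatter. The next structure, compound 4 `COc1cc(C2CN(C(=O)c3cc(OCCCC(C)(C)C(=O)O)ccn3)C2)ccc1OCc1ccc(C2CC2)cc1`, keeps the shared core and alters only the end of the chain: 1-carboxy-1-methylethyl in place of carboxy on a saturated chain carbon, three bonds along the chain from an oxygen on an aromatic ring. The change is 1-carboxy-1-methylethyl in place of carboxy, on a saturated chain carbon, three bonds along the chain from an oxygen on an aromatic ring.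

Among the measured compounds shown here, no measured step makes this change, so the evidence is indirect. Two large steps replace a hydroxy-bearing chain with a carboxy-bearing one: a number 49 percentage points higher from compound 1 to compound 3 (beyond the scatter) and a number 39 percentage points higher from compound 2 to compound 3 (beyond the scatter). Compound 4 stays on the carboxy-bearing side of that contrast. The remaining step, a number 10 percentage points higher from compound 1 to compound 2 (within the scatter), shows an added hydroxymethyl on the chain changing little, but it comes from a single pair. With compound 3 at 100%, any real move in this assay would be downward, though no step beyond the scatter is expected. The expected size is a number 8 percentage points lower from compound 3 to compound 4 (within the scatter). Compound 4 is estimated at 92%, with an expected range from 72% to 100%.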

Compound 4, percent of the compound remaining: 64%
The estimate for compound 4 lay 28 percentage points above the measured number; the measured number lies below the stated range.
By their numbers in this assay, from the lowest: compounds 1, 2 and 4 (each within the scatter of the next, the first and the last beyond it); then compound 3.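

In this assay a carboxy group on the chain does not by itself hold the top of the series: 1-carboxy-1-methylethyl in place of carboxy, on a saturated chain carbon, three bonds along the chain from an oxygen on an aromatic ring, gives a number 36 percentage points lower from compound 3 to compound 4 (beyond the scatter), so the chain end around the carboxy group matters at this position. The advantage over the hydroxy-bearing chains also narrows, with a number 13 percentage points higher from compound 1 to compound 4 (beyond the scatter) where the unbranched chain gave a number 49 percentage points higher from compound 1 to compound 3 (beyond the scatter), and a number 3 percentage points higher from compound 2 to compound 4 (within the scatter) leaves compound 4 not separated from the diol-bearing compound 2 in this read-out. No supporting measurement is available to explain the difference between the two carboxy-bearing chains.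

The step combines added chain length with branching at the carbon bearing the carboxy group, so the compounds shown do not assign the loss to either feature. An unbranched 4-carboxybutyl chain would separate length from branching, while a 2-carboxy-2-methylpropyl chain would test the branched end on a shorter chain.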